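Replacing a dimethoxyphenyl with phenethyl on the shared core

A few compounds are considered here, and "the series" means these few. Any claim that something is new, unique, unknown or untested is made for them only; others in the source may bear on it.

Compound 1 `C=C(Br)C(=O)Nc1cccc(-c2cn3nc(-c4ccc(OC)c(OC)c4)sc3n2)c1` gives 610 nM in a functional assay on HeLa cells (Homo sapiens) for inhibition, read by cell counting, with a stated time of 4 days (on this read-out higher numbers stand for weaker inhibition and lower numbers for stronger inhibition), the lowest of the two numbers recorded; in this assay compound 2 `COc1cccc(-c2nn3cc(-c4cccc(N)c4)nc3s2)c1` gives 230000 nM, a gap far beyond the scatter. Compound 3 `C=C(Br)C(=O)Nc1cccc(-c2cn3nc(CCc4ccccc4)sc3n2)c1` has not yet been measured in this assay. It differs from compound 1 by phenethyl in place of 3,4-dimethoxyphenyl on an aromatic carbon. Within the data shown here, no step between measured compounds of this kind has been recorded, so compound 3 is expected to show a modest weakening, a 2.5-fold higher number from compound 1 to compound 3 (0.39 log units; beyond the scatter), perhaps within or just beyond the scatter. Compound 3 is therefore estimated at 1500 nM, with a likely range from 400 nM to 6000 nM.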

Compound 3, half-maximal inhibitory concentration: 3300 nM
Estimate against measurement, compound 3: 2.2-fold (0.34 log units) below; the range from low to high includes it.
By their numbers in this assay, from the lowest: compound 1; then compound 3; then compound 2.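

In this assay, phenethyl in place of 3,4-dimethoxyphenyl on this aromatic carbon gives a 5.4-fold higher number from compound 1 to compound 3 (0.73 log units; beyond the scatter) and thus weakens inhibition without abolishing it. The position therefore keeps measurable inhibition with a carbon-only group that has no hydrogen-bond acceptors. No evidence here accounts for the size of this step.

This single step changes both the methoxy groups and the chain, so it leaves open which of the two matters. An unsubstituted phenyl at this position, or an amine at the end of a longer chain, remains unaddressed by the compounds shown.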